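This account rests on a few compounds, and the source may have more. Where it says the series, first, only, none or still open, it means among the compounds named here.

The measured compounds:
Compound 1, `O=C1N=C(O)S/C1=C\c1ccc(OCCC2CCCCC2)cc1Cl`, gives 13 nM in an assay for inhibition of 15-hydroxyprostaglandin dehydrogenase [NAD(+)] (Homo sapiens), read by fluorescence and spectrophotometry; a lower number here means a stronger inhibitor, a higher number a weaker inhibitor.
Compound 2, `CC(C)OCCOc1ccc(/C=C2\SC(O)=NC2=O)cc1Cl`, gives 2740 nM in this assay.
Compound 3, `O=C1NC(=O)/C(=C/c2ccc(OCC3CCCC3)c(Cl)c2)S1`, gives 11 nM in this assay.

Among these three numbers compound 1 stands second highest. Its nearest neighbour is compound 3, whose value lies within the usual scatter of that of compound 1, so the two cannot be told apart on these data even though their structures differ in several places. Compound 2 stands far higher, well beyond the scatter, and is therefore a much weaker inhibitor than compound 1 in this assay.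

The unmeasured compound 4, `O=C1N=C(O)S/C1=C\c1ccc(OCCc2ccccc2)cc1Cl`, differs from compound 1 in one place: phenyl in place of cyclohexyl on a saturated chain carbon, two bonds along the chain from an oxygen on an aromatic ring. Among the measured compounds shown here, no pair of measured compounds shows this same exchange, so there is no measured step to lean on; what the measured set does show is that compound 1 and compound 3 sit close together while compound 2 falls far behind. For the exchange of cyclohexyl for phenyl the step of a 1.7-fold higher number from compound 1 to compound 4 (0.23 log units; within the scatter) is expected to be small, leaning if anything toward a slightly higher number, and not clearly beyond the scatter. Compound 4 is thus estimated at 22 nM, with a range from 7 nM to 70 nM.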

Compound 4, half-maximal inhibitory concentration: 178 nM
Compound 4: the middle estimate sits 8.1-fold (0.91 log units) below what was measured; measured number above the stated range.
By their numbers in this assay, from the lowest: compounds 3 and 1 (each within the scatter of the next); then compound 4; then compound 2.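

In this assay the exchange of cyclohexyl for phenyl, on a saturated chain carbon, two bonds along the chain from an oxygen on an aromatic ring, gives a 14-fold higher number from compound 1 to compound 4 (1.14 log units; beyond the scatter) and counts as a large step, beyond the scatter. Among the compounds shown here, this is the first single-place change in the set, and it shows that this position does not accept any ring of matching size equally: the two groups have the same heavy-atom, donor and acceptor counts, and the aromatic one gives the weaker inhibitor in this pair. Nothing at hand accounts for the size of this step, so the change can be described but not explained.

On these data alone, whether a pyridine ring or a cyclohexenyl ring at this place would fall nearer to compound 1 or to compound 4 remains open. The finding also rests on a single pair, so it is unsettled whether the same exchange would carry a similar step on a longer chain.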